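Phenyl to 4-Methylbenzyl on the Ring Amine Nitrogen

The source may hold more compounds than are shown below. What is called first, only, known or untested is meant among the compounds shown, and "the series" means these compounds.

Among the measured compounds shown here, compound 2 `Cn1c(-c2ccc(NC(=O)CN3CCN(c4ccccc4)CC3)cc2)nc(-c2ccccc2)c1-c1ccccc1` is the higher of the two compounds measured so far. In a functional assay on HT-29 cells (Homo sapiens) for cytotoxicity, read by MTT assay, with a stated time of 24 h, tested at 0.64 ug/mL (on this read-out higher numbers stand for a stronger effect at the one concentration tested and lower numbers for a weaker effect), compound 2 gives 17.3%, whereas compound 1 `CN(C)/C=C/N1CCN(CC(=O)Nc2ccc(-c3nc(-c4ccccc4)c(-c4ccccc4)n3C)cc2)CC1` gives 3.1%. For the measured compounds named here, the one step measured, a number 14.2 percentage points higher from compound 1 to compound 2 (beyond the scatter), concerns the same place on the shared core: the amine nitrogen in a ring.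

Compound 3 `Cc1ccc(CN2CCN(CC(=O)Nc3ccc(-c4nc(-c5ccccc5)c(-c5ccccc5)n4C)cc3)CC2)cc1` differs from compound 2 at that same place: 4-methylbenzyl in place of phenyl on an amine nitrogen in a ring. Going by the values given here, the only step that bears on this change is the one from compound 1 to compound 2, a modest rise beyond the scatter when phenyl entered on the ring nitrogen. Among the compounds with values here, no measured step tells what 4-methylbenzyl in place of phenyl does at this position, so the expectation for compound 3 rests on compound 2 alone and is wide.

Compound 3 is therefore expected to stay close to compound 2, with a step of a number 2.7 percentage points higher from compound 2 to compound 3 (within the scatter), which is not beyond the scatter. Compound 3 is estimated at 20%, within a range from 6% to 40%.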

Compound 3, a percentage reported as activity, at one concentration (the size of the read-out at that concentration, not a potency): 15.4%
The estimate for compound 3 lay 4.6 percentage points above the measured number; low and high end bracket the measured number.
By their numbers in this assay, from the lowest: compound 1; then compounds 3 and 2 (each within the scatter of the next).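

In this assay, swapping phenyl for 4-methylbenzyl on the amine nitrogen in the ring gives a number 1.9 percentage points lower from compound 2 to compound 3 (within the scatter), so this read-out does not separate the two groups, even though the entering group has 8 heavy atoms against 6 and both carry one six-membered aromatic ring of carbon only. The second comparison, a number 12.3 percentage points higher from compound 1 to compound 3 (beyond the scatter), shows that the modest gap first seen with phenyl is not unique to that group: among these three compounds, both of the groups with a carbon-only aromatic ring stand beyond the scatter from 2-(dimethylamino)ethenyl, and no compound shown goes against this. No evidence is available to explain these results.

The compounds shown leave open whether the ring nitrogen would tolerate a small alkyl group such as methyl, an acetyl group, or a benzyl group carrying a carboxylic acid or an amine in place of the methyl of 4-methylbenzyl. They also leave open whether compound 2 and compound 3 would remain indistinguishable at other concentrations, since a reading at one concentration is not a potency.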